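The source may report more compounds than this note shows. Statements on the series, on what has been measured and on what is new or still open speak of the compounds shown alone.

Working notes on the series. Compound 1 `O=C(N/N=C/c1ccc(Br)cc1)c1cccnc1` is tested in an ADME assay on HeLa cells (Homo sapiens) for cytotoxicity, read by microscopy; on this read-out lower numbers stand for higher toxicity in this test and higher numbers for lower toxicity in this test. In this assay compound 1 reaches only a limit of the assay, > 100 ug/mL, not a number. Compound 2 `O=C(N/N=C/c1ccc(F)cc1)c1cccnc1` carries fluoro in place of bromo on an aromatic carbon. In this assay compound 2 likewise stops at a limit of the assay, > 100 ug/mL. The step between the two in this assay is a step that the two limits leave unreadable from compound 1 to compound 2. On the numbers shown compound 2 stands where every value so far stands: the limit of > 100 ug/mL in this assay, at which 2 of the 2 values shown sit.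

Compound 3 `O=C(N/N=C/c1ccc([N+](=O)[O-])cc1)c1cccnc1` is the next member to be measured in this assay. Its change from compound 2 is nitro in place of fluoro on an aromatic carbon. Of the measured steps only a step that the two limits leave unreadable from compound 1 to compound 2 bears on it, and that step cannot be read in size, so it gives no direction to carry forward. The expectation for compound 3 in this assay is therefore a value again at the limit of the assay. Compound 3 is thus expected to show a number no higher from compound 2 to compound 3 (the limit leaves the size open). Compound 3 is estimated at 100 ug/mL, within 50 ug/mL to 250 ug/mL.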

Compound 3, minimum cytotoxic concentration: 0.8 ug/mL
The estimate for compound 3 lay 130-fold (2.10 log units) above the measured number; measured number below the stated range.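

In this assay the group on this aromatic carbon, para to a large group, proves able to move the read-out by a wide margin: nitro in place of fluoro gives a large fall in the number (an at least 120-fold lower number from compound 2 to compound 3 (2.09 log units; beyond the scatter)), and nitro in place of bromo gives a large fall as well (an at least 120-fold lower number from compound 1 to compound 3 (2.09 log units; beyond the scatter)). Compound 3 gives 0.8 ug/mL and is the only one of the three to give a number, so the position that looked silent with the two halogens is not silent for every group. The step between the two halogen compounds cannot be read, and the series so far rests on one number with the rest at a limit of the assay: the limit of > 100 ug/mL in this assay, at which 2 of the 3 values shown sit.

Going by these compounds, the true size of the fall stays open, as does whether it belongs to nitro alone or would also appear with an amine, a nitrile or a carboxylic acid on the same carbon. The compounds shown also leave open whether nitro gives the same result on another carbon of this ring or on a changed version of the shared core.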